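Dichloro analog of the cyclohexanone sulfonamide series

The compounds below may be only part of what the source reports. "The series", "measured", "known", "first", "only" and "open" are said of these compounds alone.

Measured so far in a functional assay on KB cells (Homo sapiens) for antiproliferative activity, read by sulforhodamine B assay, tested at 100 ug/mL; on this read-out higher numbers stand for more inhibition at the one concentration tested (going by the name of the read-out) and lower numbers for less inhibition:
compound 1 `Cc1ccc(NS(=O)(=O)C2CCCCC2=O)cc1`: -22.2%
compound 2 `O=C1CCCCC1S(=O)(=O)Nc1ccc(Cl)cc1`: -3.83%

Compound 2 stands highest of the two numbers; its nearest neighbour is compound 1, lower by a step beyond the scatter. Going by the values given here, the one measured step is a number 18.4 percentage points higher from compound 1 to compound 2 (beyond the scatter), a modest rise.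

Compound 3 `O=C1CCCCC1S(=O)(=O)Nc1ccc(Cl)c(Cl)c1` has not yet been measured. It differs from compound 2 by chloro in place of hydrogen on an aromatic carbon.

Among the compounds with values here, only the step from compound 1 to compound 2 bears on this change, as it is the only case where a chloro group enters the aromatic ring, and it was modest and upward. The change to compound 3 is a second chloro of the same kind, so a step of similar size and direction, or none beyond the scatter, is expected in this assay; the step expected from compound 2 to compound 3 is a number 11.8 percentage points higher from compound 2 to compound 3 (beyond the scatter). For compound 3 the estimate is 8%, in a range from -12% to 30%.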

Compound 3, a percentage reported as inhibition, at one concentration (the size of the read-out at that concentration, not a potency): 17.8%
Beside the measured number, compound 3's estimate is 9.8 percentage points below it; measured number inside the range.
By their numbers in this assay, from the lowest: compound 1; then compound 2; then compound 3.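

In this assay, a chloro group in place of hydrogen on the aromatic carbon ortho to a chloro group and meta to a large group gives a number 21.6 percentage points higher from compound 2 to compound 3 (beyond the scatter), so the read-out keeps rising with a second chloro group. This step adds a group to the ring rather than exchanging one group for another, and it moves the read-out from a negative value, with compound 2 at -3.83%, to a positive one, with compound 3 at 17.8%. No accompanying measurement accounts for this rise.

From the compounds shown here alone, whether the rise belongs to chloro itself remains open; a methoxy group, a trifluoromethyl group or an amine on the same aromatic carbon would test that. Going by these compounds, with one concentration per compound, potency also remains open.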